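Notes on the step from compound 2 to compound 3

The compounds below may be only part of what the source reports. "The series", "measured", "known", "first", "only" and "open" are said of these compounds alone.

Measured in a functional assay on DU-145 cells (Homo sapiens) for cytotoxicity, read by MTT assay, with a stated time of 72 h; on this read-out higher numbers stand for weaker inhibition and lower numbers for stronger inhibition:
compound 1 `COc1cc(/C=C/C(=O)Nc2cc(C(=O)c3cc(OC)c(OC)c(OC)c3)ccc2OC)ccc1F` gives 12100 nM
compound 2 `COc1ccc(C(=O)c2cc(OC)c(OC)c(OC)c2)cc1NC(=O)/C=C/c1ccc(N)cc1` gives 13500 nM

Compound 2 and compound 1 give numbers within the scatter of each other, so neither stands apart on this read-out. Going by the values given here, the single measured step, a 1.1-fold higher number from compound 1 to compound 2 (0.05 log units; within the scatter), exchanged the aryl ring at the end of the ethenyl chain and left the number essentially where it was.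

Compound 3 `COc1ccc(C(=O)c2cc(OC)c(OC)c(OC)c2)cc1NC(=O)/C=C/c1ccc([N+](=O)[O-])cc1` differs from compound 2 by nitro in place of amino on an aromatic carbon. Among the compounds with values here, no measured step exchanges amino for nitro, so the only step that bears on this change is a 1.1-fold higher number from compound 1 to compound 2 (0.05 log units; within the scatter), which stayed within the scatter although it replaced the whole terminal aryl group. In this assay a step of a 1.0-fold lower number from compound 2 to compound 3 (0.02 log units; within the scatter) is therefore expected, that is, none beyond the scatter. Compound 3 is estimated at 13000 nM, with a range of 5500 nM to 32000 nM.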

Compound 3, half-maximal inhibitory concentration: 15600 nM
The estimate for compound 3 lay 1.2-fold (0.08 log units) below the measured number; low and high end bracket the measured number.
By their numbers in this assay, from the lowest: compounds 1, 2 and 3 (each within the scatter of the next).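

On the aromatic carbon para to a large group, the exchange of amino for nitro gives a 1.2-fold higher number from compound 2 to compound 3 (0.06 log units; within the scatter), so in this assay these two groups, which differ in heavy atoms and hydrogen-bond donors, are not told apart. The wider exchange of the terminal aryl group gives a 1.3-fold higher number from compound 1 to compound 3 (0.11 log units; within the scatter), so 4-nitrophenyl joins 4-aminophenyl and 4-fluoro-3-methoxyphenyl as terminal groups that cannot be separated on this read-out. No further evidence bears on this result.

On these data alone, whether any group on this aromatic carbon can move the number beyond the scatter stays open, for instance a carboxylic acid, a dimethylamino group or a longer alkyl chain. Also open, as far as these compounds go, is whether the read-out responds to a change in the shared core rather than at the end of the ethenyl chain.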